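The source may hold more compounds than are shown below. What is called first, only, known or untested is meant among the compounds shown, and "the series" means these compounds.

Compound 1 `Cc1cc(C)cc(OCC(=O)Nc2nc(-c3ccccc3)n[nH]2)c1`: 2700 nM
Compound 2 `O=C(COc1ccccc1)Nc1nc(-c2ccc(F)cc2)n[nH]1`: 1500 nM

Of the compounds shown here, two of the shared core have been measured in an assay on CHO cells for displacement of a labelled ligand from adenosine receptor A3 (Homo sapiens), read by scintillation counting, with a stated time of 60 min; on this read-out lower numbers stand for stronger inhibition and higher numbers for weaker inhibition. Compound 2 stands at the lower end of the two numbers, yet its gap to compound 1 falls within the usual scatter of repeated measurements, so the two cannot be told apart on these data. Compound 3 `Cc1ccc(-c2n[nH]c(NC(=O)COc3ccccc3)n2)cc1` is the next member to be tested. Relative to compound 2 the change is methyl in place of fluoro on an aromatic carbon, a methyl in place of fluoro on an aromatic carbon, para to a large group. Among the measured compounds shown here, no pair of measured compounds shows this particular exchange, so there is no measured step to lean on; a shift of at most the scatter, in no firm direction, is the reasonable expectation. The expected step of no change at the digits printed from compound 2 to compound 3 (within the scatter) is therefore nothing beyond the scatter. Compound 3 is estimated at 1500 nM, with a range from 600 nM to 4000 nM.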

Compound 3, inhibition constant: 3200 nM
For compound 3 the middle estimate is 2.1-fold (0.33 log units) below the measured one; measured number inside the range.
By their numbers in this assay, from the lowest: compounds 2, 1 and 3 (each within the scatter of the next, the first and the last beyond it).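

In this assay, among the compounds shown here, the exchange of 4-fluorophenyl for 4-methylphenyl gives a 2.1-fold higher number from compound 2 to compound 3 (0.33 log units; beyond the scatter) and is the first single-place step that can be read. It shows that the number responds to the group on this aromatic carbon, para to a large group, with fluoro giving the lower number of the two, although this rests on one pair and the step is modest. Nothing measured here explains the step.

The compounds shown leave open how an amine, a methoxy group, a chlorine or a bare hydrogen at this position would compare with fluoro and methyl. They also leave open whether the same exchange would give a similar step on a compound carrying the other end of compound 1.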